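Amide aryl variation on the shared core: two limits so far

This account rests on a few compounds, and the source may have more. Where it says the series, first, only, none or still open, it means among the compounds named here.

Compound 2 `O=C(Nc1ccc(Cl)c(-c2nnc3c(Cl)cccn23)c1)c1c(F)cccc1Cl` is one of two amides measured on the shared core. In a functional assay on T47D cells (Homo sapiens) for antiproliferative activity, read by MTT assay, with a stated time of 72 h (on this read-out higher numbers stand for weaker inhibition and lower numbers for stronger inhibition), compound 2 gives > 100000 nM, which is a limit of the assay and not a number. Compound 1 `O=C(Nc1ccc(Cl)c(-c2nnc3c(Cl)cccn23)c1)c1ccc(Cl)cc1` differs only in the aryl on the carbonyl carbon; in this assay compound 1 likewise gives > 100000 nM, again a limit. The step that the two limits leave unreadable from compound 1 to compound 2 is therefore not readable, as the limit of > 100000 nM in this assay, at which 2 of the 2 values shown sit, shows. Compound 3 `O=C(Nc1ccc(Cl)c(-c2nnc3c(Cl)cccn23)c1)c1ccccc1` carries phenyl in place of 2-chloro-6-fluorophenyl on a carbonyl carbon. With no readable measured step, no change beyond the scatter is expected for a step that the limit leaves unreadable from compound 2 to compound 3. Compound 3 is expected to give 150000 nM, between 30000 nM and 1000000 nM.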

Compound 3, half-maximal inhibitory concentration: > 100000 nM
Compound 3: only a limit was reported; the forecaster's own chance of this, stated with the estimate: 80%; the middle value does not contradict the limit.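

Within the data shown here, no step among compound 1, compound 2 and compound 3 can be read, because all three values are limits and not numbers: the limit of > 100000 nM in this assay, at which 3 of the 3 values shown sit.
Left open is whether any amide aryl on the shared core gives a measurable value in this assay.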